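One Fluoro Change on the Only Measured Compound

A few compounds are considered here, and "the series" means these few. Any claim that something is new, unique, unknown or untested is made for them only; others in the source may bear on it.

Compound 1 (`Oc1nc2ccc(Cc3ccccc3)cc2o1`) with 77.2 mg/kg as a measured number
Compound 2 (`CN(C)CCn1c(=O)oc2cc(C(=O)c3ccccc3)ccc21`) with > 120 mg/kg as a limit
Compound 3 (`CCC(=O)c1ccc2c(c1)oc(=O)n2CCN1CCCCC1`) with > 100 mg/kg as a limit

All three compounds were tested in a functional assay on the whole organism for inhibition, with Mus musculus as the target (a lower number here means that less compound is needed, a higher number that more compound is needed for the effect), and only compound 1 has a measured number. Compound 2 stands at > 120 mg/kg and this value is a limit. Compound 3 stands at > 100 mg/kg and this value is also a limit.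

Compound 4 (`Oc1nc2ccc(Cc3ccc(F)cc3)cc2o1`) differs from compound 1 in one place: fluoro in place of hydrogen on an aromatic carbon that is, fluoro in place of hydrogen on an aromatic carbon. Going by the values given here, no pair of measured compounds differs in one place, so the data offer no step to scale from. Among the compounds with values here, the expectation in this assay is therefore a step no larger than the scatter, in no firm direction, starting from compound 1 at 77.2 mg/kg as the only number available. The expected step is a 1.1-fold lower number from compound 1 to compound 4 (0.04 log units; within the scatter) and it stays modest. For compound 4 the estimated value is 70 mg/kg with an expected range from 32 mg/kg to 140 mg/kg and the measurement is still to come.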

Compound 4, dose for half-maximal effect: 218 mg/kg
Estimate against measurement, compound 4: 3.1-fold (0.49 log units) below; the measured number lies above the stated range.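

In this assay, going by these compounds alone, fluoro in place of hydrogen on an aromatic carbon, para to a large group, gives a 2.8-fold higher number from compound 1 to compound 4 (0.45 log units; beyond the scatter) and supplies the first step that can be read. Within the data shown here, until then no two measured compounds differed in one place, so nothing showed whether this position responded to any change at all. The position does respond to the addition of a single fluorine atom, and in this pair the change goes towards more compound being needed for the effect.

As far as these compounds go, whether chloro, methoxy or an amine on the same carbon would move the number in the same direction, and whether fluoro elsewhere on that ring would do so, stays open with this single step. Nothing in the data given bears on why the step goes this way.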